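A few compounds are considered here, and "the series" means these few. Any claim that something is new, unique, unknown or untested is made for them only; others in the source may bear on it.

Measured so far in an ADME assay on microsomes from liver (Homo sapiens) for metabolic stability, using NADPH, with a stated time of 10 min; a higher number here means that more of the compound is left, a lower number that less of the compound is left
Compound 1 (`CN(C)[C@@H]1CCN(c2cccc3c2C[C@H](CN(C)[C@H]2CCCc4cccnc42)NC3)C1`) – "not determined" (no result reported)
Compound 2 (`CN(C[C@H]1Cc2c(cccc2N2C[C@H]3CCN(C)[C@H]3C2)CN1)[C@H]1CCCc2cccnc21`) – 97.6%

Among the compounds with values here, compound 2 holds the only number, and compound 1 has no result to set against it. Compound 3 (`CN1C[C@@H]2CN(c3cccc4c3C[C@H](CN(C)[C@H]3CCCc5cccnc53)NC4)C[C@@H]2C1`) has the same atoms as compound 2, joined differently, with the change on an aromatic carbon of the shared core (a group of 9 heavy atoms (7 carbon, 2 nitrogen; 2 five-membered non-aromatic rings with 1 hetero atom each) in place of a group of 9 heavy atoms (7 carbon, 2 nitrogen; 2 five-membered non-aromatic rings with 1 hetero atom each), on an aromatic carbon). Within the data shown here, no measured step is available. In this assay no change beyond the scatter is expected, and compound 2 at 97.6% leaves room mainly downward. The estimated step of a number 5.6 percentage points lower from compound 2 to compound 3 (within the scatter) stays within the usual scatter. Compound 3 is expected at 92% with an estimated range from 75% to 100% in this measurement.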

Compound 3, percent of the compound remaining: 100%
The estimate for compound 3 lay 8 percentage points below the measured number; the range from low to high includes it.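

In this assay, within the data shown here, the first readable step at this position is a number 2.4 percentage points higher from compound 2 to compound 3 (within the scatter). On this aromatic carbon of the shared core, one arrangement of the group with 2 five-membered non-aromatic rings can thus replace the other, with the same atoms, without a difference beyond the scatter. No available measurement bears on the reason for this result.

Still open, on these data alone, is how a morpholine or a carboxylic acid on this aromatic carbon would read out. The compounds shown also leave open whether any group here gives a lower percent remaining.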